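The compounds below may be only part of what the source reports. "The series", "measured", "known", "first", "only" and "open" are said of these compounds alone.

Of the compounds shown here, three that share one core have been tested in an assay on HEK293 cells for inhibition of Voltage-dependent T-type calcium channel subunit alpha-1G (Homo sapiens), read by fluorescence, tested at 10 uM; a higher number here means more inhibition at the concentration tested (going by the name of the read-out), a lower number less inhibition. Compound 1 `CCCc1nc(-c2ccccc2)c(CNCCCN2CCN(c3ccccc3F)CC2)o1` gives 54.4%. Compound 2 `CCCc1nc(-c2ccccc2)c(CNCCN2CCN(c3ccccc3F)CC2)o1` gives 46.5% in this assay, the second highest of the three numbers; its nearest neighbour is compound 1, and the furthest is compound 3 `Cc1nc(-c2ccccc2)c(CNCCCN2CCN(c3ccc(Cl)cc3)CC2)o1`, which gives 38.1% in this assay. Both gaps lie inside the usual scatter, so no order among the three can be read from them. Compound 4 `CCCc1nc(-c2ccccc2)c(CNCCN2CCN(c3ccc(C(F)(F)F)cc3)CC2)o1` has not yet been measured. It differs from compound 2 in one place: 4-(trifluoromethyl)phenyl in place of 2-fluorophenyl on an amine nitrogen in a ring. Within the data shown here, no pair of measured compounds shows this change alone, so no measured step guides it. Compound 4 is expected to give 45%, within 25% to 65%. The step of a number 1.5 percentage points lower from compound 2 to compound 4 (within the scatter) that this estimate means is expected to stay within the scatter, in no clear direction.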

Compound 4, a percentage reported as inhibition, at one concentration (the size of the read-out at that concentration, not a potency): 58.7%
Compound 4: middle estimate off by 13.7 percentage points, on the low side; the measured number falls inside the stated range.
By their numbers in this assay, from the lowest: compounds 3, 2, 1 and 4 (each within the scatter of the next, the first and the last beyond it).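

In this assay, the swap gives a number 12.2 percentage points higher from compound 2 to compound 4 (beyond the scatter) and is the only step shown so far, so the group on this ring nitrogen can move the read-out. The swap alters both the substituent on the phenyl ring and where it sits, so the two changes cannot be told apart here. Nothing available gives a cause for the step.

Going by these compounds, it remains open whether 4-fluorophenyl or 2-(trifluoromethyl)phenyl would separate those two changes. On these data alone, the same swap on the longer chain of compound 1 also remains open.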